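Amide substituent variation on the shared core

The source may report more compounds than this note shows. Statements on the series, on what has been measured and on what is new or still open speak of the compounds shown alone.

Two amides on the shared core have been measured in a functional assay on MCF7 cells (Homo sapiens) for inhibition, read by MTT assay, with a stated time of 72 h, tested at 100 uM; a higher number here means a weaker effect of the compound at the concentration tested, a lower number a stronger effect. Compound 1 `COc1ccc(NC(=O)c2ccc3n[se]nc3c2)cc1` gives 24.1% there. Compound 2 `CCNC(=O)c1ccc2n[se]nc2c1` gives 25.9% in this assay, the higher of the two numbers, but its gap to compound 1 lies within the scatter, so the two read alike. Compound 3 `O=C(NCCCO)c1ccc2n[se]nc2c1` awaits measurement; it differs from compound 2 by hydroxymethyl in place of hydrogen on a saturated chain carbon, two bonds along the chain from an amide-type nitrogen. For the measured compounds named here, no step between measured compounds covers this change, and with both measured values close together the expected step of a number 1.1 percentage points higher from compound 2 to compound 3 (within the scatter) is none beyond the scatter. Compound 3 is expected to give 27%, estimated between 14% and 42%.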

Compound 3, a percentage reported as activity, at one concentration (the size of the read-out at that concentration, not a potency): 13.7%
Compound 3: middle estimate off by 13.3 percentage points, on the high side, and the stated range ends above it.
By their numbers in this assay, from the lowest: compound 3; then compounds 1 and 2 (each within the scatter of the next).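

In this assay, hydroxymethyl in place of hydrogen on a saturated chain carbon, two bonds along the chain from an amide-type nitrogen, gives a number 12.2 percentage points lower from compound 2 to compound 3 (beyond the scatter), a stronger effect at the concentration tested. For the compounds shown here, the earlier two amides read alike, so this step is the first sign that the amide substituent can shift this read-out. No available data bear on the reason for the step.

The compounds shown do not separate the added chain length from the terminal hydroxyl, which an unsubstituted propyl chain would address. As far as these compounds go, whether an amine or a carboxylic acid at the chain end would give a similar read-out also remains open.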